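The source may hold more compounds than are shown below. What is called first, only, known or untested is meant among the compounds shown, and "the series" means these compounds.

Measured so far:
- compound 1, `CCC(CC)(c1nnc[nH]1)c1ccc(-c2ccc3cc(F)cc(F)c3c2)[nH]c1=O`: 350 nM
- compound 2, `CC(C)C(Cc1nnc[nH]1)c1ccc(-c2ccc3cccc(F)c3c2)[nH]c1=O`: 17 nM

Notes on the series. In a functional assay on CHO cells for antagonist activity at prostaglandin E2 receptor EP3 subtype (Homo sapiens), read by cAMP accumulation (on this read-out higher numbers stand for weaker inhibition and lower numbers for stronger inhibition), compound 2 gives 17 nM, the lowest of the two numbers; compound 1 gives 350 nM, a gap beyond the usual scatter. Among the compounds with values here, no step between measured compounds is available, so nothing is known yet about swapping the group on the chain carbon.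

Compound 3, `CC(C)C(c1ccc(-c2ccc3cccc(F)c3c2)[nH]c1=O)N1CCNC1=O`, differs from compound 2 as follows: 2-oxoimidazolidin-1-yl in place of (4H-1,2,4-triazol-3-yl)methyl on a saturated chain carbon bound to an aromatic carbon and a saturated chain carbon.

Within the data shown here, with no comparable step in hand, the estimate for compound 3 rests on compound 2 alone: a moderate move toward weaker inhibition, a 2.9-fold higher number from compound 2 to compound 3 (0.47 log units; beyond the scatter), is expected. Compound 3 is estimated at 50 nM, within 15 nM to 200 nM.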

Compound 3, half-maximal inhibitory concentration: 28 nM
For compound 3 the middle estimate is 1.8-fold (0.25 log units) above the measured one; the range from low to high includes it.
By their numbers in this assay, from the lowest: compounds 2 and 3 (each within the scatter of the next); then compound 1.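

In this assay, within the data shown here, the step of a 1.6-fold higher number from compound 2 to compound 3 (0.22 log units; within the scatter) is the first swap read at this place on the saturated chain carbon. The five-membered aromatic ring with 3 hetero atoms of compound 2 and the non-aromatic 2-oxoimidazolidin-1-yl ring of compound 3 give values within the scatter of each other, so an aromatic ring here is not required for a value in this range. Nothing on hand bears on why the two groups read alike.

Open, from the compounds shown here alone, is whether an amine, a carboxylic acid or a longer chain at this place would keep such a value. Also open, going by these compounds, is whether the same swap would read alike on the core of compound 1.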